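The source may hold more compounds than are shown below. What is called first, only, known or untested is meant among the compounds shown, and "the series" means these compounds.

Measured in a functional assay on WM-115 cells (Homo sapiens) for cytotoxicity, read by MTT assay, with a stated time of 46 h; on this read-out higher numbers stand for weaker inhibition and lower numbers for stronger inhibition:
compound 1 `O=C1/C(=C/c2ccncc2)C(c2ccccc2)Oc2ccccc21`: 6300 nM
compound 2 `O=C1/C(=C/c2ccccc2)C(c2ccccc2)Oc2ccccc21`: 59400 nM
compound 3 `O=C1/C(=C/c2ccc(Cl)cc2)C(c2ccccc2)Oc2ccccc21`: 52000 nM

Compound 3 sits with compound 2 at the high-number end of these three values. Still unmeasured is compound 4 `O=C1/C(=C/c2ccc(Br)cc2)C(c2ccccc2)Oc2ccccc21`, with bromo in place of chloro on an aromatic carbon, para to a large group: bromo in place of chloro on an aromatic carbon. The closest measured change is chloro in place of hydrogen on an aromatic carbon, which gave a 1.1-fold lower number from compound 2 to compound 3 (0.06 log units; within the scatter). The larger steps, a 9.4-fold higher number from compound 1 to compound 2 (0.97 log units; beyond the scatter) and an 8.3-fold higher number from compound 1 to compound 3 (0.92 log units; beyond the scatter), replace pyridin-4-yl and bear on this change only weakly. No step beyond the scatter is therefore expected in this assay. The estimated step is a 1.0-fold lower number from compound 3 to compound 4 (0.02 log units; within the scatter). For compound 4 the estimated value is 50000 nM, with an expected range of 28000 nM to 90000 nM.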

Compound 4, half-maximal inhibitory concentration: 25900 nM
Compound 4: middle estimate off by 1.9-fold (0.29 log units), on the high side; the whole stated range lies above it.
By their numbers in this assay, from the lowest: compound 1; then compounds 4, 3 and 2 (each within the scatter of the next, the first and the last beyond it).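

In this assay, bromo alone among the halogens shown separates from the unsubstituted phenyl (a 2.3-fold lower number from compound 2 to compound 4 (0.36 log units; beyond the scatter)), yet bromo and chloro themselves cannot be told apart (a 2.0-fold lower number from compound 3 to compound 4 (0.30 log units; within the scatter)). Pyridin-4-yl still gives the lowest number (a 4.1-fold higher number from compound 1 to compound 4 (0.61 log units; beyond the scatter)), although this step is smaller than the one to the unsubstituted phenyl (a 9.4-fold higher number from compound 1 to compound 2 (0.97 log units; beyond the scatter)). No measurement on hand accounts for the bromo result. Still open, on these data alone, is whether fluoro, methoxy, an amine or a carboxylic acid at this place would give a number nearer that of compound 1. Also open, as far as these compounds go, is how pyridin-3-yl would compare with pyridin-4-yl.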